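Compound 3 to compound 4: halogens give way to ethoxy

The compounds below may be only part of what the source reports. "The series", "measured", "known", "first", "only" and "open" are said of these compounds alone.

In a functional assay on L1210 cells (Mus musculus) for antiproliferative activity (on this read-out lower numbers stand for stronger inhibition and higher numbers for weaker inhibition), compound 1 (`COc1cc(C(=O)c2sc(-c3ccc(Cl)cc3)cc2N)cc(OC)c1OC`) gives 93 nM, the strongest of the three measured compounds. Compound 2 (`COc1cc(C(=O)c2sc(-c3ccc(I)cc3)cc2N)cc(OC)c1OC`) gives 400 nM and compound 3 (`COc1cc(C(=O)c2sc(-c3ccc(Cl)c(Cl)c3)cc2N)cc(OC)c1OC`) gives 260 nM. These last two values lie within the scatter of each other, and both stand clearly on the weak side of compound 1.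

The next compound is compound 4 (`CCOc1ccc(-c2cc(N)c(C(=O)c3cc(OC)c(OC)c(OC)c3)s2)cc1`), with 4-ethoxyphenyl in place of 3,4-dichlorophenyl on an aromatic carbon, next to the ring sulfur: 4-ethoxyphenyl in place of 3,4-dichlorophenyl on an aromatic carbon.

For the measured compounds named here, three measured steps bear on this change, all among halogen-bearing aryl groups. The series shows a 4.3-fold higher number from compound 1 to compound 2 (0.63 log units; beyond the scatter), a 2.8-fold higher number from compound 1 to compound 3 (0.45 log units; beyond the scatter) and a 1.5-fold lower number from compound 2 to compound 3 (0.19 log units; within the scatter). The first two are modest and the third stays within the scatter. Going by the values given here, no measured compound carries an ethoxy group, so these steps give a scale for changes at this place but no firm direction. Compound 3 at 260 nM sits toward the weak end of the measured range, which leaves more room for a lower number than for a higher one. The expected step is a 2.2-fold lower number from compound 3 to compound 4 (0.34 log units; beyond the scatter), modest in size and downward. For compound 4 the estimated value is 120 nM, with an expected range of 35 nM to 400 nM.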

Compound 4, half-maximal inhibitory concentration: 590 nM
Beside the measured number, compound 4's estimate is 4.9-fold (0.69 log units) below it, outside the stated range (above it).
By their numbers in this assay, from the lowest: compound 1; then compounds 3, 2 and 4 (each within the scatter of the next, the first and the last beyond it).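

Ethoxy is the first non-halogen group seen on this aryl ring, and in this assay it gives no gain: the change shows as a 2.3-fold higher number from compound 3 to compound 4 (0.36 log units; beyond the scatter) and as a 6.3-fold higher number from compound 1 to compound 4 (0.80 log units; beyond the scatter) in the comparison with the best compound so far, both steps modest. Against the iodo compound the swap reads as a 1.5-fold higher number from compound 2 to compound 4 (0.17 log units; within the scatter) and so cannot be told apart from it, which places compound 4 with compound 2 and leaves compound 1 clearly stronger than each of the other three. At this place, next to the ring sulfur, 4-ethoxyphenyl brings a hydrogen-bond acceptor that 3,4-dichlorophenyl lacks, yet within these four compounds that acceptor goes with a higher number, and a non-halogen group has so far offered no route past the chloro compound.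

On these data alone, whether a shorter methoxy, a longer propoxy chain or an amine such as dimethylamino on the same phenyl ring would fall with compound 1 or with compound 4 remains open. Nothing available on these compounds gives a reason for the higher number of compound 4.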